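The source may report more compounds than this note shows. Statements on the series, on what has been measured and on what is new or still open speak of the compounds shown alone.

Working notes on the series. Compound 1 `CCCCc1nc2cccnc2n1Cc1cc(Cl)c(O)c(Cl)c1` gives 63.1 nM in a functional assay (aorta) with Oryctolagus cuniculus as the target; a lower number here means tighter binding, a higher number weaker binding. Compound 2 `CCCc1nc2cccnc2n1Cc1cc(Cl)c(O)c(Cl)c1` gives 31.6 nM in this assay. The change from compound 2 to compound 1 is methyl in place of hydrogen on a saturated chain carbon, three bonds along the chain from an aromatic carbon.

Compound 3 `CSc1nc2c(C)ccnc2n1Cc1ccc(-c2ccccc2C(=O)O)cc1` sits on a different core; the difference between the two cores is not broken down here. In this assay compound 3 gives 10 nM, the lowest of the three numbers.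

Compound 4 `CCSc1nc2c(C)ccnc2n1Cc1ccc(-c2ccccc2C(=O)O)cc1` is not yet measured. It differs from compound 3 by methyl in place of hydrogen on a saturated chain carbon bound to a sulfur. Among the measured compounds shown here, this is the same kind of change as the one from compound 2 to compound 1, not the same: there the added carbon sits three bonds along the chain from an aromatic carbon, here on a saturated chain carbon bound to a sulfur.

The step from compound 3 to compound 4 is expected to be small, a 1.4-fold higher number from compound 3 to compound 4 (0.15 log units; within the scatter), because the matching step between compound 2 and compound 1 gave a 2.0-fold higher number from compound 2 to compound 1 (0.30 log units; within the scatter). Compound 4 is therefore estimated at 14 nM in this assay, with a range from 5 nM to 35 nM.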

Compound 4, dissociation constant: 5.01 nM
Estimate against measurement, compound 4: 2.8-fold (0.45 log units) above; the range from low to high includes it.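

In this assay the new step is a 2.0-fold lower number from compound 3 to compound 4 (0.30 log units; within the scatter), which on its own gives no firm sign of an effect of the added methyl on the core of compound 3. The comparison rests on one pair per core, with the added carbon at a different place in each pair, and it does not separate the role of the core from that of the place. It does show that, for these two pairs, the change does not carry over from one core to the other as a fixed shift: the same change on two cores in this assay, a 2.0-fold higher number (0.30 log units; within the scatter) from compound 2 to compound 1 and a 2.0-fold lower number (0.30 log units; within the scatter) from compound 3 to compound 4, 4.0-fold (0.60 log units) apart, beyond the scatter of two such steps

Still open, as far as these compounds go, is how a longer chain on the sulfur, such as propylsulfanyl, would read on the core of compound 3. An amine in place of the ethylsulfanyl group is also left open.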